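Side chain swap at the aryl ether, compound 1 to 4

A few compounds are considered here, and "the series" means these few. Any claim that something is new, unique, unknown or untested is made for them only; others in the source may bear on it.

The series is followed in a functional assay on A549 cells (Homo sapiens) for cytotoxicity, read by MTT assay, with a stated time of 48 h; a lower number here means a stronger inhibitor, a higher number a weaker inhibitor. For the measured compounds named here, compound 1 `COc1c(OCc2cnoc2C)cc(O)c2c(=O)cc(-c3ccccc3)oc12` is the only member with a reading, and that reading is a limit of the assay rather than a number: in this assay compound 1 gives > 100000 nM. Compound 2 `O=c1cc(-c2ccccc2)oc2c(OCCCCNC3CCCCC3)c(O)cc(O)c12` has no result in this assay, recorded as "not determined" (no result reported). Compound 3 `O=c1cc(-c2ccccc2)oc2c(OCCNCCO)c(O)cc(O)c12` likewise stands at "not determined" (no result reported). Going by the values given here, no step between two measured compounds is therefore available, and the one piece of evidence is the limit of > 100000 nM in this assay, at which 1 of the 3 values shown sits.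

Compound 4 `CCN(CC)CCCCOc1cc(O)c2c(=O)cc(-c3ccccc3)oc2c1OC` is the next compound for this assay. It differs from compound 1 in one place: 3-(diethylamino)propyl in place of 5-methyl-1,2-oxazol-4-yl on a saturated chain carbon bound to an oxygen on an aromatic ring. With compound 1 at the limit and nothing else measured, no direction for the change can be read from the data. The step from compound 1 to compound 4 is expected to be an at least 1.6-fold lower number from compound 1 to compound 4 (0.22 log units; that floor lies within the scatter), which is to say a move downward from the limit is possible but not secured. Compound 4 is therefore estimated at 60000 nM in this assay, with the range running from 15000 nM to 200000 nM, and a fair chance remains that only a limit is reported again.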

Compound 4, half-maximal inhibitory concentration: 1000 nM
For compound 4 the middle estimate is 60-fold (1.78 log units) above the measured one, outside the stated range (below it).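

At the aryl ether, 4-(diethylamino)butoxy in place of (5-methyl-1,2-oxazol-4-yl)methoxy gives an at least 100-fold lower number from compound 1 to compound 4 (2.00 log units; beyond the scatter) in this assay and brings the series to its first reading that is an actual number. The change at this one place is therefore enough to bring the compound inside the range of the assay, with the shared core otherwise unchanged. The step is a floor and not a full size, because compound 1 stands at a limit of the assay: the limit of > 100000 nM in this assay, at which 1 of the 4 values shown sits.

The oxazole ring leaves and the amine chain enters in the same step, so the two contributions cannot be separated, and steps to compounds 2 and 3 cannot be read. A plain butyl ether without nitrogen, a 4-(dimethylamino)butoxy chain or a shorter aminoalkoxy chain at this place would address that question.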